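A hydroxyphenyl exchange among compounds held at the limit

This account rests on a few compounds, and the source may have more. Where it says the series, first, only, none or still open, it means among the compounds named here.

Compound 1 `CCc1ccc(-c2nc3c(c(C)nn3-c3ccccc3)c(-c3ccccc3C#N)c2C#N)cc1` and compound 2 `CCc1ccc(-c2nc3c(c(C)nn3-c3ccccc3)c(-c3ccccc3Br)c2C#N)cc1` and compound 3 `CCc1ccc(-c2nc3c(c(C)nn3-c3ccccc3)c(-c3ccccc3C(F)(F)F)c2C#N)cc1` share a core and differ in one substituent on the aryl group opposite the ring nitrogen. In an ADME assay on BJ cells (Homo sapiens) for cytotoxicity, with a stated time of 72 h (on this read-out lower numbers stand for an effect already at smaller amounts and higher numbers for an effect only at larger amounts of compound), compound 1 gives > 20000 nM as a limit and not a number. Compound 2 gives > 20000 nM as a limit as well. Compound 3 also gives > 20000 nM as a limit, so it has no number of its own. What the series offers so far is the limit of > 20000 nM in this assay, at which 3 of the 3 values shown sit, and no ranking can be drawn from it.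

The step to compound 4 `CCc1ccc(-c2nc3c(c(C)nn3-c3ccccc3)c(-c3ccc(O)cc3)c2C#N)cc1`, not yet measured, is 4-hydroxyphenyl in place of 2-(trifluoromethyl)phenyl on an aromatic carbon and puts 4-hydroxyphenyl in place of 2-(trifluoromethyl)phenyl at that same carbon. Among the compounds with values here, two measured steps bear on it, a step that the two limits leave unreadable from compound 1 to compound 3 and a step that the two limits leave unreadable from compound 2 to compound 3 and neither has a size that can be read. Within the data shown here, no measured compound carries a 4-hydroxyphenyl group. The data therefore support no expected change beyond the scatter in this assay and no direction. The expected outcome is a number no higher from compound 3 to compound 4 (the limit leaves the size open) with compound 4 most likely reported as a limit again. The estimate for compound 4 is 20000 nM with an expected range from 8000 nM to 40000 nM in a numerical reading.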

Compound 4, half-maximal effective concentration: > 20000 nM
Compound 4 was reported as a limit; the forecaster's own chance of this, stated with the estimate: 75%; the middle value lies on the limit itself.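

Compound 4 is again reported only as a limit, so its steps from compound 1, compound 2 and compound 3 cannot be read, and the series rests on a single ceiling: the limit of > 20000 nM in this assay, at which 4 of the 4 values shown sit.

The compounds shown leave open whether the four aryl groups differ from one another at all in this assay.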